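Reaching from a benzyl thioether toward a pentyl chain

The source may report more compounds than this note shows. Statements on the series, on what has been measured and on what is new or still open speak of the compounds shown alone.

Compound 1 `Cc1ccc(CSc2n[nH]c(-n3[se]c4ccccc4c3=O)n2)cc1` is the reference point. In a functional assay on SMMC-7721 cells (Homo sapiens) for antiproliferative activity, read by CCK-8 assay, with a stated time of 48 h (a lower number here means a stronger inhibitor, a higher number a weaker inhibitor), compound 1 gives > 50000 nM, which is a limit of the assay and not a number (the limit of > 50000 nM in this assay, at which 1 of the 2 values shown sits). Compound 2 `CCCCSc1n[nH]c(-n2[se]c3ccccc3c2=O)n1` carries a butyl thioether on the shared core, and in this assay compound 2 gives 16800 nM. Among the compounds with values here, the single measured step, an at least 2.9-fold lower number from compound 1 to compound 2 (0.47 log units; beyond the scatter), puts propyl in place of 4-methylphenyl on a saturated chain carbon bound to a sulfur and lowers the number beyond the scatter. Compound 3 `CCCCCSc1n[nH]c(-n2[se]c3ccccc3c2=O)n1` differs from compound 1 by butyl in place of 4-methylphenyl on a saturated chain carbon bound to a sulfur, which cut one bond further out reads 4-methylbenzyl to pentyl. The measured step bears directly on this change and was at least modest, so a lowering of similar size is expected in this assay. Compound 3 is therefore estimated at 14000 nM, with a range from 5000 nM to 40000 nM. The expected step is an at least 3.5-fold lower number from compound 1 to compound 3 (0.55 log units; beyond the scatter).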

Compound 3, half-maximal inhibitory concentration: 31400 nM
Compound 3: the middle estimate sits 2.2-fold (0.35 log units) below what was measured, and the stated range covers the measured number.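

In this assay, methyl in place of hydrogen on the butyl chain gives a 1.9-fold higher number from compound 2 to compound 3 (0.27 log units; within the scatter), so the pentyl and butyl thioethers cannot be told apart at this position. The change from 4-methylbenzyl to pentyl gives an at least 1.5-fold lower number from compound 1 to compound 3 (0.20 log units; that floor lies within the scatter), so unlike the change to the butyl thioether, this one is not shown to lower the number beyond the scatter. Compound 1 stands at a limit of the assay and not at a number: the limit of > 50000 nM in this assay, at which 1 of the 3 values shown sits.

The compounds shown leave open how a longer chain such as hexyl, or a chain ending in an amine or a carboxylic acid, would read on this sulfur. They also leave open whether an unsubstituted benzyl group would read like the 4-methylbenzyl group of compound 1.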